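The compounds below may be only part of what the source reports. "The series", "measured", "known", "first", "only" and "open" are said of these compounds alone.

Compound 1 `COc1cc(-c2nnc(SCC(=O)c3ccccc3)n2N)cc(OC)c1OC` carries a benzoyl group on the shared core. In a functional assay on HeLa cells (Homo sapiens) for antiproliferative activity, read by MTT assay, with a stated time of 48 h (on this read-out lower numbers stand for stronger inhibition and higher numbers for weaker inhibition), compound 1 gives > 100000 nM, which is only a limit of the assay, (the limit of > 100000 nM in this assay, at which 1 of the 3 values shown sits). Two measured partners alter one aromatic hydrogen of that benzoyl group. Compound 2 `COc1cc(-c2nnc(SCC(=O)c3ccc(Cl)cc3)n2N)cc(OC)c1OC` gives 13100 nM, a step of an at least 7.6-fold lower number from compound 1 to compound 2 (0.88 log units; beyond the scatter). Compound 3 `COc1cc(-c2nnc(SCC(=O)c3ccc(C)cc3)n2N)cc(OC)c1OC` gives 2940 nM, a step of an at least 34-fold lower number from compound 1 to compound 3 (1.53 log units; beyond the scatter); between the two partners lies a 4.5-fold lower number from compound 2 to compound 3 (0.65 log units; beyond the scatter). Compound 4 `COc1cc(-c2nnc(SCC(=O)c3cccc(Br)c3)n2N)cc(OC)c1OC` is not yet measured; it differs from compound 1 by bromo in place of hydrogen on an aromatic carbon. Both measured steps from compound 1 lowered the number beyond the scatter. A lowering step is therefore expected for compound 4 as well, an at least 6.6-fold lower number from compound 1 to compound 4 (0.82 log units; beyond the scatter), closer in size to the chloro step than to the methyl step. Compound 4 is estimated at 15000 nM, between 4000 nM and 60000 nM.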

Compound 4, half-maximal inhibitory concentration: 77500 nM
Compound 4: middle estimate off by 5.2-fold (0.71 log units), on the low side; the whole stated range lies below it.
By their numbers in this assay, from the lowest: compound 3; then compound 2; then compound 4. At a limit, above all of these: compound 1.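

In this assay, the bromo change can be read only as a floor, an at least 1.2-fold lower number from compound 1 to compound 4 (0.11 log units; that floor lies within the scatter), since compound 1 stands at a limit of the assay: the limit of > 100000 nM in this assay, at which 1 of the 4 values shown sits. A substituent on this ring therefore no longer guarantees a clear drop in the number. The 3-bromophenyl group also falls well behind the 4-chlorophenyl group, with a 5.9-fold higher number from compound 2 to compound 4 (0.77 log units; beyond the scatter), and further behind the 4-methylphenyl group, with a 26-fold higher number from compound 3 to compound 4 (1.42 log units; beyond the scatter).

These two steps change both the substituent and its place, so the compounds shown do not separate those effects. On these data alone, how a 4-bromophenyl group, or an amine or carboxylic acid on this ring, would read remains open.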